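This account rests on a few compounds, and the source may have more. Where it says the series, first, only, none or still open, it means among the compounds named here.

Compound 2, `COc1cc2c(Oc3ccc(NC(=O)c4cc(-c5cccc(Cl)c5)nc5ccc(F)cc45)cc3F)ccnc2cc1OCCCN1CCC(C)CC1`, gives 110 nM in a functional assay on U-87MG ATCC cells (Homo sapiens) for cytotoxicity, read by MTT assay, with a stated time of 72 h (on this read-out lower numbers stand for stronger inhibition and higher numbers for weaker inhibition), and holds the lowest number among the three compounds measured. Compound 1, `COc1cc2c(Oc3ccc(NC(=O)c4cc(-c5cccc(Cl)c5)nc5ccccc45)cc3F)ccnc2cc1OCCCN1CCC(C)CC1`, gives 580 nM in this assay, and the step of a 5.3-fold lower number from compound 1 to compound 2 (0.72 log units; beyond the scatter) separates the two. Compound 3, `COc1cccc(-c2cc(C(=O)Nc3ccc(Oc4ccnc5cc(OCCCN6CCC(C)CC6)c(OC)cc45)c(F)c3)c3cc(F)ccc3n2)c1`, gives 840 nM in this assay, and the step of a 7.6-fold higher number from compound 2 to compound 3 (0.88 log units; beyond the scatter) lies between compound 2 and compound 3.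

Compound 4, `COc1cc2c(Oc3ccc(NC(=O)c4cc(-c5cccc(Cl)c5)nc5ccc(F)cc45)cc3F)ccnc2cc1OCCCN1CCCC1`, has not been measured in this assay. It differs from compound 2 in one place: pyrrolidin-1-yl in place of 4-methylpiperidin-1-yl on a saturated chain carbon, three bonds along the chain from an oxygen on an aromatic ring. Neither of the measured steps touches this part of the molecule. The step from compound 1 to compound 2 and the step from compound 2 to compound 3 both alter aromatic substituents, so they give no direct guide to an exchange of the cyclic amine at the end of the propyl chain. For the measured compounds named here, with no measured step bearing on the change, the expectation is that compound 4 shows no step beyond the scatter in this assay, expressed as a 1.4-fold higher number from compound 2 to compound 4 (0.13 log units; within the scatter), though the range allows for a departure in either direction. Compound 4 is therefore estimated at 150 nM in this assay, with a range from 50 nM to 500 nM.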

Compound 4, half-maximal inhibitory concentration: 990 nM
The estimate for compound 4 lay 6.6-fold (0.82 log units) below the measured number, and the stated range ends below it.
By their numbers in this assay, from the lowest: compound 2; then compounds 1, 3 and 4 (each within the scatter of the next).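

Until now, every measured step in this assay had altered an aromatic substituent, so nothing had shown whether the cyclic amine on the saturated chain affects this read-out. Compound 4 shows that it does: pyrrolidin-1-yl in place of 4-methylpiperidin-1-yl gives a 9.0-fold higher number from compound 2 to compound 4 (0.95 log units; beyond the scatter) in this read-out, so this position is not a silent one, and among the two amines compared here the 4-methylpiperidin-1-yl goes with the lower number. No measurement offered here accounts for this step, so its cause stays unknown.

The exchange changes the ring from six-membered to five-membered and removes the methyl group in a single move, so the compounds shown leave open which of the two matters, a question that an unsubstituted piperidin-1-yl group at the end of the same propyl chain would help to settle. They also leave open how a morpholin-4-yl or a dimethylamino group would read at this place, and whether the same amine exchange would give a step of similar size on compound 1 or compound 3.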